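The compounds below may be only part of what the source reports. "The series", "measured", "known", "first", "only" and "open" are said of these compounds alone.

Working notes on the series sharing the core of compound 1, `Cc1cn([C@H]2C[C@H](NC(=O)CC(=O)O)[C@@H](CO)O2)c(=O)[nH]c1=O`. In an assay on isolated protein for inhibition of ribonuclease pancreatic (Homo sapiens), read by spectrophotometry, using a Dixon plot (on this read-out lower numbers stand for stronger inhibition and higher numbers for weaker inhibition), compound 1 gives 380000 nM. Compound 2, `Cc1cn([C@H]2C[C@H](NC(=O)CCC(=O)O)[C@@H](CO)O2)c(=O)[nH]c1=O`, carries the longer acid chain; in this assay compound 2 gives 918000 nM, which is the higher of the two numbers recorded so far, and the step of a 2.4-fold higher number from compound 1 to compound 2 (0.38 log units; beyond the scatter) lies beyond the scatter. Compound 3, `Cc1cn([C@H]2C[C@H](NC(=O)C(=O)O)[C@@H](CO)O2)c(=O)[nH]c1=O`, is not yet measured. Its difference from compound 2 is carboxy in place of 2-carboxyethyl on a carbonyl carbon, placed on a carbonyl carbon whose other neighbour is the amide-type nitrogen. Among the compounds with values here, the only measured step that bears on this change is the lengthening from compound 1 to compound 2, where adding one chain carbon raised the number modestly; removing two chain carbons in the other direction is therefore expected to lower the number, and the step from compound 2 to compound 3 is estimated as a 3.7-fold lower number from compound 2 to compound 3 (0.56 log units; beyond the scatter). For compound 3 in this assay the expected value is 250000 nM, in the range 80000 nM to 800000 nM.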

Compound 3, inhibition constant: 132000 nM
Beside the measured number, compound 3's estimate is 1.9-fold (0.28 log units) above it; the measured number falls inside the stated range.
By their numbers in this assay, from the lowest: compound 3; then compound 1; then compound 2.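

Shortening the chain in this assay gives a 7.0-fold lower number from compound 2 to compound 3 (0.84 log units; beyond the scatter) and, with the shorter starting chain, a 2.9-fold lower number from compound 1 to compound 3 (0.46 log units; beyond the scatter) on the same carbonyl carbon, so the lower number is not confined to the longest chain. The three compounds now fall in one order, carboxy, then carboxymethyl, then 2-carboxyethyl, with the number rising along it, none going against it, and each step beyond the scatter. The series thus has its lowest number so far with carboxy placed directly on the carbonyl carbon, but nothing shown gives a reason for this order.

Going by these compounds, it remains open whether the carboxylic acid itself is needed for this order, which a methyl ester or a primary amide in its place would test. On these data alone, it is also open whether a chain longer than 2-carboxyethyl continues the rise.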